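A few compounds are considered here, and "the series" means these few. Any claim that something is new, unique, unknown or untested is made for them only; others in the source may bear on it.

Measured compounds in the series:

Compound 1, `Cc1cc(C#N)cc(C)c1Oc1ccc(N)c(Nc2ccc(C#N)cc2)n1`. In an ADME assay on MT2 cells (Homo sapiens) for cytotoxicity, read by XTT assay, with a stated time of 4 days (on this read-out lower numbers stand for higher toxicity in this test and higher numbers for lower toxicity in this test), compound 1 reaches only a limit of the assay, > 100000 nM.
Compound 2, `Cc1cc(Br)cc(C)c1Oc1ccc([N+](=O)[O-])c(Nc2ccc(C#N)cc2)n1`; in this assay compound 2 gives 65100 nM.
Compound 3, `C=CCc1cc(C)c(Oc2ccc([N+](=O)[O-])c(Nc3ccc(C#N)cc3)n2)c(C)c1`; in this assay compound 3 gives 39700 nM.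

Compound 3 holds the lowest of the two numbers given, with compound 2 nearest; the step of a 1.6-fold lower number from compound 2 to compound 3 (0.21 log units; within the scatter) lies within the scatter, so the two are not separated. Going by the values given here, the one further value, that of compound 1, is a limit and not a number (the limit of > 100000 nM in this assay, at which 1 of the 3 values shown sits).

Compound 4, `CC(=O)/C=C/c1cc(C)c(Oc2ccc([N+](=O)[O-])c(Nc3ccc(C#N)cc3)n2)c(C)c1`, differs from compound 3 in one place: 2-acetylethenyl in place of allyl on an aromatic carbon. Among the compounds with values here, the only measured step at this aromatic carbon is a 1.6-fold lower number from compound 2 to compound 3 (0.21 log units; within the scatter), which exchanged one small group for another without leaving the scatter. Within the data shown here, no measured step replaces an allyl with a 2-acetylethenyl, so the series gives no ground for a move beyond the scatter in this assay in either direction. Compound 4 is therefore expected to give 40000 nM, between 15000 nM and 100000 nM. The expected step is a 1.0-fold higher number from compound 3 to compound 4 (0.00 log units; within the scatter), within the scatter.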

Compound 4, half-maximal cytotoxic concentration: > 47900 nM
Compound 4: a limit, no number; the forecaster's own chance of this, stated with the estimate: 20%; at least 1.1-fold (0.07 log units) between middle value and limit.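

Going by these compounds alone, at this aromatic carbon, 2-acetylethenyl in place of allyl gives an at least 1.2-fold higher number from compound 3 to compound 4 (0.08 log units; that floor lies within the scatter) in this assay, so this is the first reading for a group here with a hydrogen-bond acceptor. Compound 4 reaches only a limit of the assay, > 47900 nM in this assay, and this limit is not a number. The position, para to a large group, therefore accepts a group with more heavy atoms and a second double bond outside the aromatic rings, with no lower number shown relative to compound 3.

Going by these compounds, the step from compound 2 to compound 4 cannot be read, and the true size of the step to compound 4 stays open: the limit of > 47900 nM in this assay, at which 1 of the 4 values shown sits. On these data alone, whether an amine, a carboxylic acid or a longer chain on this carbon would move the number beyond the scatter also remains open.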